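The source may hold more compounds than are shown below. What is called first, only, known or untested is meant among the compounds shown, and "the series" means these compounds.

In a functional assay on NCI-H520 cells (Homo sapiens) for inhibition, read by MTT assay, with a stated time of 48 h, tested at 10 uM (a higher number here means more inhibition at the concentration tested (going by the name of the read-out), a lower number less inhibition), compound 1 `COc1cc(NC(=O)Nc2cc(Nc3cc(I)ccc3OC)ncn2)cc(OC)c1` gives 55%. Compound 2 `COc1cc(NC(=O)Nc2cc(Nc3ccc(OC)c(I)c3)ncn2)cc(OC)c1` gives 46.5% in this assay, and the step of a number 8.5 percentage points lower from compound 1 to compound 2 (within the scatter) places the two compounds within the scatter of each other, so compound 2 stands alongside compound 1 rather than apart from it. Compound 3 `COc1cc(NC(=O)Nc2cc(Nc3cc(C)cc(F)c3)ncn2)cc(OC)c1` differs from compound 2 by 3-fluoro-5-methylphenyl in place of 3-iodo-4-methoxyphenyl on a nitrogen on an aromatic ring. Within the data shown here, the single measured step swapped one iodo-methoxyphenyl for another without a change beyond the scatter; no measured step removes iodine or brings in fluorine and methyl, so the expected step of a number 4.5 percentage points lower from compound 2 to compound 3 (within the scatter) is small and uncertain. Compound 3 is estimated at 42%, between 20% and 65%.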

Compound 3, a percentage reported as inhibition, at one concentration (the size of the read-out at that concentration, not a potency): 24.5%
Compound 3: the middle estimate sits 17.5 percentage points above what was measured; the range from low to high includes it.
By their numbers in this assay, from the lowest: compound 3; then compounds 2 and 1 (each within the scatter of the next).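

In this assay this place on the nitrogen proves sensitive to more than a shift of the same groups: 3-fluoro-5-methylphenyl in place of 3-iodo-4-methoxyphenyl gives a number 22 percentage points lower from compound 2 to compound 3 (beyond the scatter) and in place of 5-iodo-2-methoxyphenyl gives a number 30.5 percentage points lower from compound 1 to compound 3 (beyond the scatter) beyond what the earlier step showed. Nothing available explains this fall. From the compounds shown here alone, compound 3 loses iodine and methoxy and gains fluorine and methyl together, so which of these changes carries the step stays open. Going by these compounds, whether a chlorine in place of the iodine, or an amine on this ring, would keep the number is also open.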